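The compounds below may be only part of what the source reports. "The series", "measured", "known", "first", "only" and "open" are said of these compounds alone.

Measured in an ADME assay on A549 cells (Homo sapiens) for cytotoxicity, read by MTT assay, with a stated time of 72 h; on this read-out lower numbers stand for stronger inhibition and higher numbers for weaker inhibition:
- compound 1 `O=C1Nc2ccc([N+](=O)[O-])cc2/C1=C\c1ccccn1`: "not toxic" (no number reported)
- compound 2 `O=C1Nc2ccc([N+](=O)[O-])cc2C1=Cc1cccnc1`: 429000 nM
- compound 3 `Cc1ccc(C(=O)/C=C2\C(=O)Nc3ccccc32)cc1`: 18700 nM

Compound 1 has no place on the numerical scale of this assay. It is reported only as "not toxic" (no number reported), and no number accompanies that verdict. The two numbers available belong to other structures, and compound 3 reads lower than compound 2 by a wide margin.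

The compound now in question is compound 4 `O=C1Nc2ccc(Br)cc2/C1=C\c1ccccn1`, which keeps the core of compound 1. The change is bromo in place of nitro on an aromatic carbon, with bromo in place of nitro on an aromatic carbon. For the measured compounds named here, no measured pair shows this exchange directly, so any expectation is tentative. A step of moderate size towards stronger inhibition is expected, although its size cannot be measured from a compound without a number. The nitro-bearing compound 2 gives 429000 nM, while compound 3, which has no nitro, gives 18700 nM. Compound 4 is expected to fall within or near that span. For compound 4 the estimated value in this assay is 100000 nM, with an expected range of 20000 nM to 450000 nM.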

Compound 4, half-maximal inhibitory concentration: 90600 nM
For compound 4 the middle estimate is 1.1-fold (0.04 log units) above the measured one; low and high end bracket the measured number.
By their numbers in this assay, from the lowest: compound 3; then compound 4; then compound 2.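

In this assay compound 1 gives "not toxic" (no number reported) and compound 4 gives 90600 nM, and no step can be read between them. The compounds shown leave open how far bromo in place of nitro shifts cytotoxicity on the shared core. Nothing shown here offers an explanation for the value of compound 4.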